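From 3,5-difluorophenyl to 2-bromo-5-ethoxyphenyl on a shared core

A few compounds are considered here, and "the series" means these few. Any claim that something is new, unique, unknown or untested is made for them only; others in the source may bear on it.

Four compounds share one core and differ in the aromatic group on a saturated chain carbon bound to an aromatic carbon and an oxygen on a saturated carbon. That group is 4-nitrophenyl in compound 1 `Cc1oc2c([C@H]3CCN(C)C[C@H]3O)c(O)cc(O)c2c(=O)c1C(O)c1ccc([N+](=O)[O-])cc1`, 4-chlorophenyl in compound 2 `Cc1oc2c([C@H]3CCN(C)C[C@H]3O)c(O)cc(O)c2c(=O)c1C(O)c1ccc(Cl)cc1` and 3,5-difluorophenyl in compound 3 `Cc1oc2c([C@H]3CCN(C)C[C@H]3O)c(O)cc(O)c2c(=O)c1C(O)c1cc(F)cc(F)c1`.

In a functional assay on HL-60 cells (Homo sapiens) for inhibition, read by MTT assay, with a stated time of 48 h, tested at 10 uM (a higher number here means more inhibition of growth at the concentration tested, a lower number less inhibition of growth), compound 1 gives 0% and compound 2 gives 2%. Swapping nitro for chloro makes little difference: a number 2 percentage points higher from compound 1 to compound 2 (within the scatter). Compound 3 stands highest of the three, at 30%, with a number 30 percentage points higher from compound 1 to compound 3 (beyond the scatter) and a number 28 percentage points higher from compound 2 to compound 3 (beyond the scatter).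

Compound 4 `CCOc1ccc(Br)c(C(O)c2c(C)oc3c([C@H]4CCN(C)C[C@H]4O)c(O)cc(O)c3c2=O)c1` has not yet been measured. Its difference from compound 3 is 2-bromo-5-ethoxyphenyl in place of 3,5-difluorophenyl on a saturated chain carbon bound to an aromatic carbon and an oxygen on a saturated carbon: 2-bromo-5-ethoxyphenyl in place of 3,5-difluorophenyl at that same place. Within the data shown here, no measured compound carries this new group, so the evidence is indirect. Among the measured compounds shown here, the steps that bear on it are the two modest ones into compound 3. Going by a number 28 percentage points higher from compound 2 to compound 3 (beyond the scatter), leaving the 3,5-difluorophenyl group may give up part of that gain, though not necessarily all of it.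

The expected change is a number 15 percentage points lower from compound 3 to compound 4 (beyond the scatter), a modest drop with much uncertainty. In this assay, the estimate for compound 4 is 15%, with an expected range of 0% to 40%.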

Compound 4, percent growth inhibition at one concentration: 2%
For compound 4 the middle estimate is 13 percentage points above the measured one; the measured number falls inside the stated range.
By their numbers in this assay, from the lowest: compounds 1, 2 and 4 (each within the scatter of the next); then compound 3.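

In this assay the move away from the 3,5-difluorophenyl group proves to be a real loss, with a number 28 percentage points lower from compound 3 to compound 4 (beyond the scatter) and with nothing kept of the earlier gain. The new group also cannot be told apart from the two older ones, as the steps read no change at the digits printed from compound 2 to compound 4 (within the scatter) and a number 2 percentage points higher from compound 1 to compound 4 (within the scatter) so that 4-nitrophenyl, 4-chlorophenyl and 2-bromo-5-ethoxyphenyl all sit together in this assay despite their different substituents. Among the four groups shown at this saturated chain carbon, only 3,5-difluorophenyl stands clear of the rest, so the higher growth inhibition belongs to that one group and not to aromatic groups here in general.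

Going by these compounds, whether that gain needs both fluorine atoms stays open, since a plain phenyl, a 3-fluorophenyl or a 3,5-dichlorophenyl group, or an amine on the same ring, would each test a different part of it. Nothing in the data shown explains why 2-bromo-5-ethoxyphenyl fails to keep the level reached with 3,5-difluorophenyl.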